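Adding a Hydroxy Group to a Naphthyl Sugar Core

This account rests on a few compounds, and the source may have more. Where it says the series, first, only, none or still open, it means among the compounds named here.

Compound 1, `CO[C@@H]1[C@@H](O)[C@H](Oc2ccc3ccccc3c2)OC[C@H]1O`: 145 uM
Compound 2, `O[C@@H]1CO[C@@H](Oc2ccc3ccccc3c2)[C@H](O)C1`: 179 uM

In a functional assay on HCC70 cells (Homo sapiens) for antiproliferative activity, read by crystal violet staining, with a stated time of 96 h (a higher number here means that more compound is needed for the effect, a lower number that less compound is needed), compound 1 gives 145 uM and compound 2 gives 179 uM. Compound 2 holds the higher of the two numbers, but a 1.2-fold higher number from compound 1 to compound 2 (0.09 log units; within the scatter) keeps the pair within the scatter. Compound 3, `O[C@H]1[C@H](Oc2ccc3ccccc3c2)OC[C@@H](O)[C@H]1O`, differs from compound 2 by hydroxy in place of hydrogen on a saturated ring carbon. Among the compounds with values here, the only measured step that bears on this, a 1.2-fold higher number from compound 1 to compound 2 (0.09 log units; within the scatter), put hydrogen in place of methoxy on a saturated ring carbon without moving the number beyond the scatter, so compound 3 is expected to show a 1.1-fold lower number from compound 2 to compound 3 (0.02 log units; within the scatter), no change beyond the scatter in this assay. Compound 3 is therefore estimated at 170 uM, in the range 85 uM to 340 uM.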

Compound 3, concentration for half-maximal effect: 178 uM
Compound 3: the middle estimate sits 1.0-fold (0.02 log units) below what was measured; the measured number falls inside the stated range.
By their numbers in this assay, from the lowest: compounds 1, 3 and 2 (each within the scatter of the next).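

In this assay, placing a hydroxy group on this saturated ring carbon gives a 1.0-fold lower number from compound 2 to compound 3 (0.00 log units; within the scatter). Until now, this position had shown only the exchange of methoxy for hydrogen, so the result adds a second group, one that carries a hydrogen-bond donor, and the number still does not move beyond the scatter. The compounds shown leave open whether an amine, a carboxylic acid or a longer chain on this carbon would shift the number beyond the scatter. Nothing available gives a reason for this result.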